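Pyrazine to Pyridine on a Urea: Clearance Expected

The source may hold more compounds than are shown below. What is called first, only, known or untested is meant among the compounds shown, and "the series" means these compounds.

The measured compounds:
compound 1, `O=C(Nc1ccc(F)c(C(F)(F)F)c1)Nc1cnccn1`, 210 uL/min
compound 2, `NC(=O)c1ccc(NC(=O)Nc2ccc(F)c(C(F)(F)F)c2)cc1`, 28 uL/min
compound 3, `N#Cc1ccc(NC(=O)Nc2ccnc(C(F)(F)F)c2)cc1`, < 7 uL/min

All three were run in an ADME assay on microsomes from liver (Homo sapiens) for metabolic stability, using NADPH, with a stated time of 60 min; a higher number here means faster removal of the compound, a lower number slower removal. Among the two numbers recorded, compound 1 has the highest, with 210 uL/min. The nearest number belongs to compound 2, which in this assay gives 28 uL/min, a gap from compound 1 that lies beyond the scatter of the method. Compound 3 does not give a number at all: its result in this assay is the limit < 7 uL/min, which is the limit of < 7 uL/min in this assay, at which 1 of the 3 values shown sits.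

Compound 4, `O=C(Nc1ccncc1)Nc1ccc(F)c(C(F)(F)F)c1`, has not yet been measured. It differs from compound 1 in one place: pyridin-4-yl in place of pyrazin-2-yl on an amide-type nitrogen. For the measured compounds named here, no measured pair in this set shares that change, so there is no step to lean on. The two cores around the urea are otherwise kept, and the ring that enters is of the same size as the one that leaves, so compound 4 is expected to stay in the neighbourhood of compound 1 rather than to move toward compound 2 or compound 3. The step from compound 1 to compound 4 is estimated at a 1.1-fold higher number from compound 1 to compound 4 (0.06 log units; within the scatter), within the usual scatter. For compound 4 the expected value in this assay is 240 uL/min, with a range of 100 uL/min to 560 uL/min.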

Compound 4, intrinsic clearance in a liver preparation (reported as CLH), per the amount of preparation that the assay uses: 12 uL/min
Compound 4: middle estimate off by 20-fold (1.30 log units), on the high side, outside the stated range (below it).
By their numbers in this assay, from the lowest: compound 4; then compound 2; then compound 1. At a limit, below all of these: compound 3.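

In this assay this place on the amide-type nitrogen turns out to matter a great deal: pyridin-4-yl in place of pyrazin-2-yl gives an 18-fold lower number from compound 1 to compound 4 (1.24 log units; beyond the scatter). The ring that enters is of the same size as the one that leaves and differs from it in carrying 1 hetero atom rather than 2, so keeping the ring size does not keep the number in this series. Both ends of this step are true numbers rather than limits, and the only limit in the set, which belongs to compound 3, stays apart from it: the limit of < 7 uL/min in this assay, at which 1 of the 4 values shown sits.

The compounds shown leave open whether the step follows the count of hetero atoms in the ring or their placing, and a pyridin-3-yl or a plain phenyl on the same nitrogen would begin to separate the two. They also give no measured property that would account for the step, and they leave open whether the same change would carry over to a core other than that of compound 1.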